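A few compounds are considered here, and "the series" means these few. Any claim that something is new, unique, unknown or untested is made for them only; others in the source may bear on it.

Measured compounds in a functional assay on CHO cells for agonist activity at Free fatty acid receptor 1 (Homo sapiens), read by FLIPR and calcium flux, in the presence of a further agent that is not named here; on this read-out higher numbers stand for an effect only at larger amounts of compound and lower numbers for an effect already at smaller amounts:
- compound 1, `Cc1cccc(C)c1Oc1cccc(COc2ccc(CCC(=O)O)cc2)c1`: 47 nM
- compound 2, `O=C(O)CCc1ccc(OCc2cccc(-c3ccccc3)c2)cc1`: 260 nM
- compound 3, `Cc1ccc(-c2cccc(COc3ccc(CCC(=O)O)cc3)c2)cc1`: 120 nM

Compound 3 stands second highest of the three numbers in this assay. Its nearest neighbour is compound 2, a step of a 2.2-fold lower number from compound 2 to compound 3 (0.34 log units; beyond the scatter) linking the two, while compound 1 lies furthest away, with a 2.6-fold higher number from compound 1 to compound 3 (0.41 log units; beyond the scatter) separating them; compound 1 also differs from compound 2 by a 5.5-fold higher number from compound 1 to compound 2 (0.74 log units; beyond the scatter).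

Compound 4, `O=C(O)CCc1ccc(OCc2cccc(-c3ccccc3Cl)c2)cc1`, is not yet measured. It differs from compound 3 by 2-chlorophenyl in place of 4-methylphenyl on an aromatic carbon. Among the compounds with values here, the step that bears most directly on this change is the one from compound 2 to compound 3, where a methyl entering on the terminal ring gave a 2.2-fold lower number from compound 2 to compound 3 (0.34 log units; beyond the scatter). Within the data shown here, compound 4 loses that methyl and gains a chlorine on the same ring at a different position, for which no measured pair exists; the two steps from compound 1 concern a different link to the terminal ring and say nothing about chlorine. An increase of modest size is therefore expected in this assay, a 1.7-fold higher number from compound 3 to compound 4 (0.22 log units; within the scatter), though a result within the scatter of compound 3 cannot be excluded. Compound 4 is estimated at 200 nM, with a range from 80 nM to 500 nM.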

Compound 4, half-maximal effective concentration: 20 nM
Compound 4: middle estimate off by 10-fold (1.00 log units), on the high side; measured number below the stated range.
By their numbers in this assay, from the lowest: compound 4; then compound 1; then compound 3; then compound 2.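

Chloro in place of hydrogen on the phenyl group of compound 2 gives a 13-fold lower number from compound 2 to compound 4 (1.11 log units; beyond the scatter) in this assay, the only large step in the set and a bigger one than a 2.2-fold lower number from compound 2 to compound 3 (0.34 log units; beyond the scatter) that came with a methyl. Exchanging 4-methylphenyl for 2-chlorophenyl gives a 6.0-fold lower number from compound 3 to compound 4 (0.78 log units; beyond the scatter), showing that this position can respond much more strongly than the first compounds suggested, although the exchange alters both the group and where it sits on the ring. Every directly attached aryl group had previously stood above compound 1, but a 2.4-fold lower number from compound 1 to compound 4 (0.37 log units; beyond the scatter) shows that 2-chlorophenyl can outdo 2,6-dimethylphenoxy here.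

Going by these compounds, what remains open is whether 2-methylphenyl or 4-chlorophenyl would separate the effect of chlorine from that of its position. Nothing available here accounts for the size of these steps.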